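The compounds below may be only part of what the source reports. "The series", "measured", "known", "first", "only" and "open" are said of these compounds alone.

Measured compounds:
compound 1, `COc1cc(OC)c2c(=O)c(OCC(=O)N/N=C/c3ccc[nH]3)c(-c3cc(OC)c(OC)c(OC)c3)oc2c1`, 5610 nM
compound 2, `COc1cc(OC)c2c(=O)c(OCCCCN3CCN(C)CC3)c(-c3cc(OC)c(OC)c(OC)c3)oc2c1`, 12200 nM
compound 3, `COc1cc(OC)c2c(=O)c(OCC(=O)N/N=C/c3ccc(C)cc3)c(-c3cc(OC)c(OC)c(OC)c3)oc2c1`, 3510 nM

In a functional assay on MGC-803 cells (Homo sapiens) for cytotoxicity, read by MTT assay, with a stated time of 38 h (on this read-out lower numbers stand for stronger inhibition and higher numbers for weaker inhibition), compound 1 gives the second highest of the three numbers; its nearest neighbour is compound 3, which gives 3510 nM, and the step between them, a 1.6-fold lower number from compound 1 to compound 3 (0.20 log units; within the scatter), lies within the scatter. Compound 2 gives 12200 nM, and the step of a 2.2-fold higher number from compound 1 to compound 2 (0.34 log units; beyond the scatter) is beyond the scatter, as is a 3.5-fold lower number from compound 2 to compound 3 (0.54 log units; beyond the scatter).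

Compound 4, `COc1cc(OC)c2c(=O)c(OCC(=O)N/N=C/c3ccccn3)c(-c3cc(OC)c(OC)c(OC)c3)oc2c1`, is not yet measured in this assay. It differs from compound 1 in one place: pyridin-2-yl in place of 1H-pyrrol-2-yl on a carbon with a double bond to nitrogen. Within the data shown here, the one measured step that bears on this change is the swap of the group on the carbon with a double bond to nitrogen, a 1.6-fold lower number from compound 1 to compound 3 (0.20 log units; within the scatter), which stayed within the scatter. The steps involving compound 2 exchange a different part of the molecule and do not speak to this change. The author therefore expects no step beyond the scatter from compound 1 to compound 4, in either direction, so that a 1.1-fold lower number from compound 1 to compound 4 (0.05 log units; within the scatter) is the expected outcome. Compound 4 is estimated to give 5000 nM in this assay, with a range from 2500 nM to 10000 nM.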

Compound 4, half-maximal inhibitory concentration: 15300 nM
Compound 4: the middle estimate sits 3.1-fold (0.49 log units) below what was measured, and the stated range ends below it.
By their numbers in this assay, from the lowest: compounds 3 and 1 (each within the scatter of the next); then compounds 2 and 4 (each within the scatter of the next).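

In this assay, the group on the carbon with a double bond to nitrogen proves able to shift the number beyond the scatter: pyridin-2-yl in place of 1H-pyrrol-2-yl gives a clear step (a 2.7-fold higher number from compound 1 to compound 4 (0.44 log units; beyond the scatter)), and pyridin-2-yl in place of 4-methylphenyl gives a larger one (a 4.4-fold higher number from compound 3 to compound 4 (0.64 log units; beyond the scatter)), although the earlier swap at this place had stayed within the scatter. With pyridin-2-yl here, compound 4 no longer stands apart from compound 2, which carries the methylpiperazine-bearing chain instead (a 1.3-fold higher number from compound 2 to compound 4 (0.10 log units; within the scatter)). No measurement at hand accounts for these steps.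

The compounds shown do not separate the size of the ring from its nitrogen, and a plain phenyl, a pyridin-4-yl or a furan-2-yl at this place would bear on that. From the compounds shown here alone, how an amine or a carboxylic acid on this ring would read in this assay also stays open.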